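Cyclopropylamino for dimethylamino on the shared core

The source may hold more compounds than are shown below. What is called first, only, known or untested is meant among the compounds shown, and "the series" means these compounds.

Compound 1 `CNc1nc(/C=C/c2cc(OC)c(OC)c(OC)c2)nc2ccsc12`: > 1000000 nM, a limit
Compound 2 `COc1cc(/C=C/c2nc(N(C)C)c3sccc3n2)cc(OC)c1OC`: > 1000000 nM, a limit

Both entries come from a functional assay on L02 cells (Homo sapiens) for inhibition, read by Griess assay, with stated times of 1 h and 24 h; a higher number here means a weaker inhibitor, a lower number a stronger inhibitor. Compound 2 gives only a limit, > 1000000 nM, and so has no numeric position. The change to compound 3 `COc1cc(/C=C/c2nc(NC3CC3)c3sccc3n2)cc(OC)c1OC` is cyclopropylamino in place of dimethylamino on an aromatic carbon. For the measured compounds named here, the one measured step, a step that the two limits leave unreadable from compound 1 to compound 2, has no readable size, and the values so far share one ceiling: the limit of > 1000000 nM in this assay, at which 2 of the 2 values shown sit. No direction of change in this assay can therefore be expected, and compound 3 will probably also report a limit. The expected step is a number no higher from compound 2 to compound 3 (the limit leaves the size open). For compound 3 the estimate is 1000000 nM, with an estimated range of 100000 nM to 2000000 nM.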

Compound 3, half-maximal inhibitory concentration: > 1000000 nM
Compound 3: only a limit was reported; the forecaster's own chance of this, stated with the estimate: 80%; the middle value sits exactly at the limit.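

No step among compound 1, compound 2 and compound 3 can be read in this assay, as all three values are limits: the limit of > 1000000 nM in this assay, at which 3 of the 3 values shown sit.

Still open, from the compounds shown here alone, is how dimethylamino and cyclopropylamino compare on the shared core, and whether any compound reaches a numeric half-maximal inhibitory concentration.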